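Removing the last fluoro from the carbamate aryl of compound 3

The compounds below may be only part of what the source reports. "The series", "measured", "known", "first", "only" and "open" are said of these compounds alone.

Measured compounds:
Compound 1 `CCCCOc1ccc(C(CC)NC(=O)Oc2cccc(C(F)(F)F)c2)cc1` gives 51 nM in an assay on H4 cells for inhibition of Fatty-acid amide hydrolase 1 (Homo sapiens); on this read-out higher numbers stand for weaker inhibition and lower numbers for stronger inhibition.
Compound 2 `CCCCOc1ccc(C(CC)NC(=O)Oc2ccc(F)cc2F)cc1` gives 21 nM in this assay.
Compound 3 `CCCCOc1ccc(C(CC)NC(=O)Oc2ccc(F)cc2)cc1` gives 12 nM in this assay.

Compound 3 carries the lowest number of the three. Its gap to compound 2 is within the scatter, so the two cannot be ordered; only compound 1 stands clearly apart, its number lying beyond the scatter above that of compound 3.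

Compound 4 `CCCCOc1ccc(C(CC)NC(=O)Oc2ccccc2)cc1` has not yet been measured. Relative to compound 3 the change is hydrogen in place of fluoro on an aromatic carbon, that is, 4-fluorophenyl to phenyl on the carbamate side.

Among the compounds with values here, only one measured step bears on this: the change from compound 2 to compound 3 also removed a fluoro from an aromatic carbon of the same ring, and it gave a 1.8-fold lower number from compound 2 to compound 3 (0.24 log units; within the scatter), a step within the scatter. On that basis the removal of the remaining fluoro is expected to give a step of about a 1.5-fold higher number from compound 3 to compound 4 (0.18 log units; within the scatter), which would still lie within the scatter. Compound 4 is therefore estimated at 18 nM, with a likely range from 7 nM to 55 nM.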

Compound 4, half-maximal inhibitory concentration: 12 nM
The estimate for compound 4 lay 1.5-fold (0.18 log units) above the measured number, within the range that was stated.
By their numbers in this assay, from the lowest: compounds 3, 4 and 2 (each within the scatter of the next); then compound 1.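

Going from 4-fluorophenyl to phenyl gave no change at the digits printed from compound 3 to compound 4 (within the scatter) in this assay, and the step from 2,4-difluorophenyl to phenyl gave a 1.8-fold lower number from compound 2 to compound 4 (0.24 log units; within the scatter) on the same read-out, so neither the last fluoro nor both fluoro groups together can be shown to matter here. Hydrogen in place of trifluoromethyl is the only one of these steps to pass beyond the scatter, with a 4.3-fold lower number from compound 1 to compound 4 (0.63 log units; beyond the scatter) as its size, which sets compound 1 apart from compound 4 where the fluoro changes leave no readable difference. Nothing available explains why these steps differ in size.

What the compounds shown leave open is whether a larger or differently built group at this place, such as a methoxy, an amine or a carboxylic acid, would shift the number. They also leave open whether a chlorine or a nitrile would behave like fluoro or like trifluoromethyl.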